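Swapping a nitro for a methyl on the benzyl ring

The source may report more compounds than this note shows. Statements on the series, on what has been measured and on what is new or still open speak of the compounds shown alone.

Among the measured compounds shown here, compound 2 `O=c1c(O)c(-c2ccccc2)oc2cc(OCc3cccc([N+](=O)[O-])c3)cc(O)c12` is the only member of this small set with a plain number in an ADME assay on Huh-5-2 cells (Homo sapiens) for cytotoxicity, read by WST assay, with a stated time of 3 days; on this read-out lower numbers stand for higher toxicity in this test and higher numbers for lower toxicity in this test: in that test compound 2 gives 76000 nM. Compound 1 `O=c1c(O)c(-c2ccccc2)oc2cc(OCc3cccc(Cl)c3)cc(O)c12` reaches only a limit of the test and not a number, > 100000 nM. Compound 3 `O=c1c(O)c(-c2ccccc2)oc2cc(OCc3ccc(Br)cc3)cc(O)c12` likewise stops at a limit, > 100000 nM. These two readings are the limit of > 100000 nM in this assay, at which 2 of the 3 values shown sit. The step of an at least 1.3-fold lower number from compound 1 to compound 2 (0.11 log units; that floor lies within the scatter) and the step of an at least 1.3-fold higher number from compound 2 to compound 3 (0.11 log units; that floor lies within the scatter) are each read against a limit and each stays within the usual scatter. Compound 4 `Cc1ccc(COc2cc(O)c3c(=O)c(O)c(-c4ccccc4)oc3c2)cc1` differs from compound 2 in that (4-methylphenyl in place of 3-nitrophenyl on a saturated chain carbon bound to an oxygen on an aromatic ring). The step from compound 2 to compound 3 bears most directly on this change, since it too exchanges the 3-nitrophenyl on that same chain carbon; it reached only a limit, and no change beyond the scatter can be read from it. A small rise, likely ending at the limit again, is the most that can be expected. Compound 4 is therefore expected to give about 100000 nM, with a range from 50000 nM to 300000 nM. The expected step reads a 1.3-fold higher number from compound 2 to compound 4 (0.12 log units; within the scatter).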

Compound 4, half-maximal cytotoxic concentration: 88000 nM
Beside the measured number, compound 4's estimate is 1.1-fold (0.06 log units) above it; low and high end bracket the measured number.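

Compound 4 adds a second plain number to the set, so the exchange on this chain carbon can now be read between two real values in this assay: a 1.2-fold higher number from compound 2 to compound 4 (0.06 log units; within the scatter). Read against the compounds that stop at a limit, the steps are an at least 1.1-fold lower number from compound 3 to compound 4 (0.05 log units; that floor lies within the scatter) and an at least 1.1-fold lower number from compound 1 to compound 4 (0.05 log units; that floor lies within the scatter). The leaving 3-nitrophenyl holds nitrogen and oxygen and the entering 4-methylphenyl only carbon, yet no change beyond the scatter appears, and how far the compounds truly differ stays hidden: the limit of > 100000 nM in this assay, at which 2 of the 4 values shown sit.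

On these data alone, whether an amine or a carboxylic acid on the benzyl ring would shift the number clearly remains open. So does the effect of a longer chain between that ring and the oxygen on the shared core.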